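This account rests on a few compounds, and the source may have more. Where it says the series, first, only, none or still open, it means among the compounds named here.

Working notes on the series. Compound 1 `CNC(=O)c1cc(C(=O)N[C@H]2CC[C@H](O)CC2)n([C@@H](C)c2ccc(Cl)cc2)n1` stands in a physicochemical assay for solubility, measured as kinetic solubility (a higher number here means a more soluble compound, a lower number a less soluble compound), at >= 132 ug/mL, which is a limit of the assay and not a number. Compound 2 `CNC(=O)c1cc(C(=O)N[C@H]2CC[C@H](O)CC2)c([C@@H](C)c2cccc(Cl)c2)o1` gives >= 179 ug/mL, also a limit. Compound 3 `CNC(=O)c1cc(C(=O)N[C@H]2CC[C@H](O)CC2)n([C@@H](C)c2ccccc2Cl)n1` remains unmeasured and differs from compound 1 in one place: 2-chlorophenyl in place of 4-chlorophenyl on a saturated chain carbon bound to an aromatic nitrogen and a saturated chain carbon. For the measured compounds named here, the chlorine moves from 4-chlorophenyl to 2-chlorophenyl, and no measured step covers this change. The expected step is none beyond the usual scatter, with a step that the limit leaves unreadable from compound 1 to compound 3 as the estimate. In this assay the estimate for compound 3 is 140 ug/mL, with an expected range from 70 ug/mL to 200 ug/mL.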

Compound 3, solubility: >= 182 ug/mL
Compound 3: no number, only a limit; the forecaster's own chance of this, stated with the estimate: 65%; middle value at least 1.3-fold (0.11 log units) from the limit.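

For the compounds shown here, compound 1 and compound 3 both give only limits in this assay, and no step between them can be read. The compounds shown leave open whether 2-chlorophenyl in place of 4-chlorophenyl changes the result in this assay at all.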